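From Furan to Dihydroxyphenyl on the Carbon Double-Bonded to Nitrogen

This account rests on a few compounds, and the source may have more. Where it says the series, first, only, none or still open, it means among the compounds named here.

Compound 1 `Cc1c(C(=O)N/N=C\c2ccccc2O)oc2cccc(O)c12`: in a functional assay on PC-3 cells (Homo sapiens) for inhibition (a higher number here means a weaker inhibitor, a lower number a stronger inhibitor), compound 1 gives 8350 nM.
Compound 2 `Cc1c(C(=O)N/N=C\c2ccco2)oc2cccc(O)c12`: in this assay compound 2 gives >= 40000 nM, a limit of the assay rather than a number.

Compound 2 thus sits at the weak end of the measured pair, at the limit of >= 40000 nM in this assay, at which 1 of the 2 values shown sits. Compound 3 `Cc1c(C(=O)N/N=C\c2ccc(O)cc2O)oc2cccc(O)c12` differs from compound 2 by 2,4-dihydroxyphenyl in place of furan-2-yl on a carbon with a double bond to nitrogen. Among the compounds with values here, one measured step bears on this change: an at least 4.7-fold higher number from compound 1 to compound 2 (0.68 log units; beyond the scatter). Since the move to compound 3 reverses that direction, returning to a hydroxyphenyl ring, a gain of roughly that size in this assay is expected, an at least 5.0-fold lower number from compound 2 to compound 3 (0.69 log units; beyond the scatter). Compound 3 is therefore estimated at 8000 nM, likely between 2500 nM and 30000 nM.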

Compound 3, half-maximal inhibitory concentration: 14800 nM
The estimate for compound 3 lay 1.9-fold (0.27 log units) below the measured number; the measured number falls inside the stated range.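

In this assay, 2,4-dihydroxyphenyl in place of furan-2-yl gives an at least 2.7-fold lower number from compound 2 to compound 3 (0.43 log units; beyond the scatter), so a second hydroxy-bearing phenyl ring also reads stronger than furan-2-yl at this carbon. Compound 2 stands at a limit of the assay, so that step has no exact size: the limit of >= 40000 nM in this assay, at which 1 of the 3 values shown sits. Hydroxy in place of hydrogen on an aromatic carbon gives a 1.8-fold higher number from compound 1 to compound 3 (0.25 log units; within the scatter), so the added hydroxy brings no change that can be told from scatter.

From the compounds shown here alone, whether the ring itself or its hydroxy matters more here stays open. So does how a plain phenyl, or a phenyl carrying methoxy or an amine, would read at this carbon.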